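From nitro to bromo on the shared core

This account rests on a few compounds, and the source may have more. Where it says the series, first, only, none or still open, it means among the compounds named here.

In a functional assay on HaCaT cells (Homo sapiens) for cytotoxicity, with a stated time of 48 h (a lower number here means a stronger inhibitor, a higher number a weaker inhibitor), compound 3 (`COc1cc(OC)c(C(=O)/C=C/c2ccc([N+](=O)[O-])cc2)c(OC)c1`) gives 2800 nM and stands lowest of the three measured numbers, against compound 2 (`COc1cc(OC)c(C(=O)/C=C/c2ccc(Cl)cc2)c(OC)c1`) at 7600 nM and compound 1 (`COc1cc(OC)c(C(=O)/C=C/c2ccccc2SC)c(OC)c1`) at 7700 nM in the same read-out. Compound 4 (`COc1cc(OC)c(C(=O)/C=C/c2ccc(Br)cc2)c(OC)c1`) has bromo in place of nitro on an aromatic carbon, para to a large group. The closest evidence is a 2.7-fold lower number from compound 2 to compound 3 (0.43 log units; beyond the scatter) with nitro in place of chloro. The other measured step is a 1.0-fold lower number from compound 1 to compound 2 (0.01 log units; within the scatter) and says little about this change. If bromo tracks the chloro of compound 2, that nitro step should largely reverse. The expected step is a 2.5-fold higher number from compound 3 to compound 4 (0.40 log units; beyond the scatter) towards a higher number. Compound 4 is estimated at 7000 nM with a range from 3800 nM to 13000 nM on these data.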

Compound 4, half-maximal inhibitory concentration: 9000 nM
Beside the measured number, compound 4's estimate is 1.3-fold (0.11 log units) below it, within the range that was stated.
By their numbers in this assay, from the lowest: compound 3; then compounds 2, 1 and 4 (each within the scatter of the next).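

In this assay, replacing nitro with bromo gives a step of the same kind as replacing nitro with chloro (a 3.2-fold higher number from compound 3 to compound 4 (0.51 log units; beyond the scatter)), and chloro and bromo cannot be told apart at this aromatic carbon (a 1.2-fold higher number from compound 2 to compound 4 (0.07 log units; within the scatter)). Among the groups on this position, nitro alone stands apart from both halogens, and the 2-(methylsulfanyl)phenyl compound cannot be separated from the bromo compound either (a 1.2-fold higher number from compound 1 to compound 4 (0.07 log units; within the scatter)). Nothing measured alongside these numbers accounts for them. As far as these compounds go, whether an amine or a carboxylic acid here would sit with nitro or with the halogens remains open.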